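Amide replacement on the shared core: compound 3 to compound 4

The source may report more compounds than this note shows. Statements on the series, on what has been measured and on what is new or still open speak of the compounds shown alone.

In a functional assay on MCF7 cells (Homo sapiens) for cytotoxicity, read by MTT assay, with a stated time of 48 h (a lower number here means a stronger inhibitor, a higher number a weaker inhibitor), compound 3 `O=C(CSc1nc2ccc(NC(=O)CCl)cc2s1)NCc1ccccc1` gives 4200 nM, the lowest of the three numbers; compound 1 `COc1ccc(CNC(=O)CSc2nc3ccc(NC(=O)c4ccccc4OC)cc3s2)cc1` gives 9300 nM and compound 2 `CC(=O)Nc1ccc2nc(SCC(=O)NCc3ccccc3)sc2c1` gives 17600 nM. Compound 4 `COc1ccccc1C(=O)Nc1ccc2nc(SCC(=O)NCc3ccccc3)sc2c1` differs from compound 3 by 2-methoxyphenyl in place of chloromethyl on a carbonyl carbon. Within the data shown here, the one step measured in a single place, a 4.2-fold lower number from compound 2 to compound 3 (0.62 log units; beyond the scatter), shows that the chloromethyl group which now leaves brought a modest gain. Compound 1, which carries the same (2-methoxyphenyl)carbonyl on a core that otherwise differs from compound 4 in one further place, sits between compound 2 and compound 3. The expectation is therefore a step back toward those numbers, a 2.4-fold higher number from compound 3 to compound 4 (0.38 log units; beyond the scatter). Compound 4 is estimated at 10000 nM, with a range from 4000 nM to 25000 nM.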

Compound 4, half-maximal inhibitory concentration: 17200 nM
Compound 4: middle estimate off by 1.7-fold (0.24 log units), on the low side; measured number inside the range.
By their numbers in this assay, from the lowest: compound 3; then compounds 1, 4 and 2 (each within the scatter of the next).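

Among the groups on this carbonyl carbon, only chloromethyl stands apart so far: 2-methoxyphenyl in its place gives the step (a 4.1-fold higher number from compound 3 to compound 4 (0.61 log units; beyond the scatter)), while 2-methoxyphenyl in place of methyl stays level (a 1.0-fold lower number from compound 2 to compound 4 (0.01 log units; within the scatter)). The added aromatic ring therefore brings no measurable gain over methyl. Hydrogen in place of methoxy on an aromatic carbon also leaves the number within the scatter (a 1.8-fold higher number from compound 1 to compound 4 (0.27 log units; within the scatter)).

Open, on these data alone, is whether the chloromethyl gain depends on the chlorine itself; bromomethyl or aminomethyl on this carbonyl carbon would test that. No measurement shown accounts for the chloromethyl result.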